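This account rests on a few compounds, and the source may have more. Where it says the series, first, only, none or still open, it means among the compounds named here.

Compound 2 `O=C(Nc1ccc(-n2ncc3ccccc32)cc1)Nc1ccc(Cl)c(C(F)(F)F)c1` and compound 1 `O=C(Nc1ccc(-n2ncc3c(F)cccc32)cc1)Nc1ccc(Cl)c(C(F)(F)F)c1` share the same core and differ only where a fluoro on an aromatic carbon in compound 1 is replaced by hydrogen in compound 2. In a functional assay on Bel-7402 cells (Homo sapiens) for cytotoxicity, read by MTT assay, with a stated time of 72 h (a higher number here means a weaker inhibitor, a lower number a stronger inhibitor), compound 1 gives 16000 nM, and compound 2 gives 10600 nM. The step of a 1.5-fold lower number from compound 1 to compound 2 (0.18 log units; within the scatter) shows that this exchange leaves the read-out essentially unchanged, so compound 2 stands at the lower of two numbers that are not separated beyond the scatter.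

Compound 3 `CNc1cccc2c1cnn2-c1ccc(NC(=O)Nc2ccc(Cl)c(C(F)(F)F)c2)cc1` takes the core of compound 2 and places a methylamino in place of hydrogen on an aromatic carbon. For the measured compounds named here, only one measured step bears on this position, the step from compound 1 to compound 2, and it was within the scatter. Going by the values given here, no measured compound carries a methylamino or any comparable group, so the size and direction of the change to compound 3 rest on a single small step. On that basis compound 3 is expected to show a 1.2-fold lower number from compound 2 to compound 3 (0.07 log units; within the scatter) in this assay, no more than the scatter. Compound 3 is therefore estimated at 9000 nM, with a range from 3000 nM to 30000 nM.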

Compound 3, half-maximal inhibitory concentration: 5000 nM
The estimate for compound 3 lay 1.8-fold (0.26 log units) above the measured number, within the range that was stated.
By their numbers in this assay, from the lowest: compound 3; then compounds 2 and 1 (each within the scatter of the next).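

In this assay, for the compounds shown here, methylamino in place of hydrogen on this aromatic carbon gives a 2.1-fold lower number from compound 2 to compound 3 (0.33 log units; beyond the scatter), the first step at this position that lies beyond the scatter, since the exchange of fluoro for hydrogen had left the number essentially unchanged. Methylamino in place of fluoro at the same carbon gives a 3.2-fold lower number from compound 1 to compound 3 (0.51 log units; beyond the scatter), so compound 3 stands apart from both earlier compounds and has the lowest number of the three, and the position is shown to respond to the group it carries. Both steps are modest, however, so what the position now shows is a real but limited gain in this cytotoxicity read-out, not a large one.

The compounds shown leave open whether the gain belongs to the nitrogen or to its methyl, which a plain amine, a dimethylamino or a methoxy on the same carbon would help to separate. They also leave open whether a longer chain on that nitrogen would carry the number further down or reverse the step, and whether the same exchange would count on another carbon of this ring. The data offered here contain nothing that accounts for the step.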